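Amide aryl variation and cytotoxicity in the shared core

This account rests on a few compounds, and the source may have more. Where it says the series, first, only, none or still open, it means among the compounds named here.

The series keeps one core and varies the aryl group on the carbonyl carbon of the amide. Compound 1, `COc1ccc(-c2cnc(NC(=O)c3ccc(Br)cc3)n2C)cc1`, carries a 4-bromophenyl there; in a toxicity assay on THP-1 cells (Homo sapiens) for inhibition (on this read-out lower numbers stand for higher toxicity in this test and higher numbers for lower toxicity in this test), compound 1 reaches only the assay limit, > 100000 nM. Compound 2, `COc1ccc(-c2cnc(NC(=O)c3cnco3)n2C)cc1`, carries a 1,3-oxazol-5-yl; in this assay compound 2 likewise stops at the limit, > 100000 nM. Compound 3, `COc1ccc(-c2cnc(NC(=O)c3cccc(C)c3)n2C)cc1`, carries a 3-methylphenyl; in this assay compound 3 again gives only the limit, > 100000 nM. Accordingly the steps a step that the two limits leave unreadable from compound 1 to compound 2, a step that the two limits leave unreadable from compound 1 to compound 3 and a step that the two limits leave unreadable from compound 2 to compound 3 cannot be read, and compound 3 stands where every measured member stands, at the limit described by the limit of > 100000 nM in this assay, at which 3 of the 3 values shown sit.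

Compound 4, `COc1ccc(-c2cnc(NC(=O)c3ccccc3Cl)n2C)cc1`, is the next member: 2-chlorophenyl in place of 3-methylphenyl on a carbonyl carbon. All three measured steps bear on this change, and none of them shows any readable size, so no step beyond the scatter is expected; the estimated step is a number no higher from compound 3 to compound 4 (the limit leaves the size open). Compound 4 is therefore expected to sit at the limit as well, estimated at 100000 nM, within a range from 50000 nM to 200000 nM.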

Compound 4, half-maximal cytotoxic concentration: > 50000 nM
Compound 4: only a limit was reported (the forecaster's own chance of this, stated with the estimate: 85%); the middle value is on the limit's open side.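

In this assay compound 4 also gives only a limit, > 50000 nM, so its steps from compound 1, compound 2 and compound 3 cannot be read. The compounds shown leave open whether any aryl group on the carbonyl carbon changes toxicity in this assay.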